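A few compounds are considered here, and "the series" means these few. Any claim that something is new, unique, unknown or untested is made for them only; others in the source may bear on it.

Measured in a physicochemical assay for solubility, at pH 7.4; a higher number here means a more soluble compound, a lower number a less soluble compound:
- compound 1 `COCc1nc(Nc2ccc(C(F)(F)F)cc2)c2ccc(-c3ncccc3C(F)(F)F)cc2n1`: 0.2 ug/mL
- compound 2 `O=P(O)(O)OCc1nc(Nc2ccc(C(F)(F)F)cc2)c2ccc(-c3ncccc3C(F)(F)F)cc2n1`: > 138 ug/mL (a limit of the assay, not a number)
- compound 3 `OCCCc1nc(Nc2ccc(C(F)(F)F)cc2)c2ccc(-c3ncccc3C(F)(F)F)cc2n1`: 0.06 ug/mL

Of the two actual numbers in this assay, the lower belongs to compound 3 at 0.06 ug/mL. The nearest number is a modest step away: a 3.3-fold lower number from compound 1 to compound 3 (0.52 log units; beyond the scatter).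

Compound 4 `CS(=O)(=O)CCc1nc(Nc2ccc(C(F)(F)F)cc2)c2ccc(-c3ncccc3C(F)(F)F)cc2n1` changes the side chain of compound 3, with methylsulfonyl in place of hydroxymethyl on a saturated chain carbon, two bonds along the chain from an aromatic carbon.

Three measured steps are available, but they do not bear equally on this change. Two are large, an at least 690-fold higher number from compound 1 to compound 2 (2.83 log units; beyond the scatter) and an at least 2300-fold lower number from compound 2 to compound 3 (3.36 log units; beyond the scatter), and both involve the phosphorus-bearing group of compound 2, which compound 4 does not contain. They offer little guide here. The closer precedent is the step among side chains without phosphorus, a 3.3-fold lower number from compound 1 to compound 3 (0.52 log units; beyond the scatter). A step no larger than that modest one is therefore expected in this assay, slightly upward if it shows at all, and possibly none beyond the scatter. The expected change is a 1.7-fold higher number from compound 3 to compound 4 (0.22 log units; within the scatter). For compound 4 the estimated value is 0.1 ug/mL, with an expected range from 0.02 ug/mL to 0.5 ug/mL.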

Compound 4, solubility: 0.2 ug/mL
The estimate for compound 4 lay 2.0-fold (0.30 log units) below the measured number, and the stated range covers the measured number.
By their numbers in this assay, from the lowest: compound 3; then compounds 1 and 4 (each within the scatter of the next). At a limit, above all of these: compound 2.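

In this assay, methylsulfonyl in place of hydroxymethyl on a saturated chain carbon, two bonds along the chain from an aromatic carbon, gives a 3.3-fold higher number from compound 3 to compound 4 (0.52 log units; beyond the scatter), the first upward step shown for a side chain without phosphorus. That step does not separate the new side chain from the methoxy side chain, as (methylsulfonyl)methyl in place of methoxy gives no change at the digits printed from compound 1 to compound 4 (within the scatter). The much larger step to the phosphorus-free compound, an at least 690-fold lower number from compound 2 to compound 4 (2.83 log units; beyond the scatter), starts from compound 2, whose entry is a limit of the assay and not a number: the limit of > 138 ug/mL in this assay, at which 1 of the 4 values shown sits.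

The compounds shown leave open how an amine or a carboxylic acid at the end of this side chain would read in this assay, and whether a longer chain carrying methylsulfonyl would stay level with compound 4. Going by these compounds alone, they also leave open whether the step goes with the loss of the hydrogen-bond donor of hydroxymethyl or with the entry of the sulfur-bearing group, since the exchange alters both at once and no pair here separates them.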